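The source may hold more compounds than are shown below. What is called first, only, known or untested is meant among the compounds shown, and "the series" means these compounds.

Compound 1 `C=CCc1cc(C(C)=O)c(O)cc1OCCCCC#N` and compound 2 `C=CCc1cc(C(C)=O)c(O)cc1OCCCCCCCCC#N` share one core and differ only in the length of the chain ending in the nitrile. In an assay on isolated protein for binding affinity to leukotriene B4 receptor 1 (Homo sapiens), tested at 1 uM (a higher number here means more inhibition at the concentration tested (going by the name of the read-out), a lower number less inhibition), compound 1 gives 57%, and in this assay compound 2 gives 50%. Within the data shown here, the single measured step is a number 7 percentage points lower from compound 1 to compound 2 (within the scatter). Among the measured compounds shown here, compound 2 thus holds the lowest of the two numbers so far, with compound 1 the nearest, and the gap between them lies within the scatter, so no order between the two can be read.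

Compound 3 `C=CCc1cc(C(C)=O)c(O)cc1OCCCCCCCCCCC#N` differs from compound 2 by 2-cyanoethyl in place of cyano on a saturated chain carbon, eight bonds along the chain from an oxygen on an aromatic ring. For the measured compounds named here, the only step that bears on this change is the chain lengthening from compound 1 to compound 2, which stayed within the scatter. The expected step is therefore a number 5 percentage points lower from compound 2 to compound 3 (within the scatter), within the scatter. Compound 3 is estimated at 45%, with a range from 30% to 60%.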

Compound 3, a percentage reported as inhibition, at one concentration (the size of the read-out at that concentration, not a potency): 14%
For compound 3 the middle estimate is 31 percentage points above the measured one; the measured number lies below the stated range.
By their numbers in this assay, from the lowest: compound 3; then compounds 2 and 1 (each within the scatter of the next).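

In this assay the length of the nitrile-ending chain turns out to matter at this position: 2-cyanoethyl in place of cyano, eight bonds along the chain from an oxygen on an aromatic ring, gives a number 36 percentage points lower from compound 2 to compound 3 (beyond the scatter), although the earlier lengthening gave only a number 7 percentage points lower from compound 1 to compound 2 (within the scatter). Taken over the whole series, 6-cyanohexyl in place of cyano, four bonds along the chain from an oxygen on an aromatic ring, gives a number 43 percentage points lower from compound 1 to compound 3 (beyond the scatter), so the number that stays level between compound 1 and compound 2 does not stay level on to compound 3. Nothing at hand accounts for this sharp loss.

The compounds shown leave open whether a still longer chain would keep the number low or change it further, and where between compound 2 and compound 3 the loss sets in. They also leave open whether a carboxylic acid or an amine at the chain end, in place of the nitrile, would behave the same way at these chain lengths.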